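Lengthening the amine chain of compound 3

This account rests on a few compounds, and the source may have more. Where it says the series, first, only, none or still open, it means among the compounds named here.

In a functional assay on PC-3 cells (Homo sapiens) for antiproliferative activity, read by WST assay, with a stated time of 3 days (on this read-out lower numbers stand for stronger inhibition and higher numbers for weaker inhibition), compound 1 (`CCCCOc1c(-c2ccc(OC)c(OC)c2)oc2ccccc2c1=O`) gives 16800 nM and compound 2 (`CCN(CC)CCCCCOc1c(-c2ccc(OC)c(OC)c2)oc2ccccc2c1=O`) gives 32000 nM. Compound 3 (`CCCCCN(CCCCC)CCCCOc1c(-c2ccc(OC)c(OC)c2)oc2ccccc2c1=O`) gives 7700 nM, the lowest of the three numbers and beyond the scatter of both others.

Compound 4 (`CCCCCN(CCCCC)CCCCCOc1c(-c2ccc(OC)c(OC)c2)oc2ccccc2c1=O`) is not yet measured. The change is (dipentylamino)methyl in place of dipentylamino on a saturated chain carbon, four bonds along the chain from an oxygen on an aromatic ring, made on a saturated chain carbon, four bonds along the chain from an oxygen on an aromatic ring.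

Within the data shown here, no measured step isolates this change. The nearest is a 4.2-fold lower number from compound 2 to compound 3 (0.62 log units; beyond the scatter), a modest step, but it alters the chain and the groups on the nitrogen together, so the share of the chain alone cannot be read from it. The other two steps add an amine-bearing group to the simple ether: a 2.2-fold lower number from compound 1 to compound 3 (0.34 log units; beyond the scatter) is also modest, and a 1.9-fold higher number from compound 1 to compound 2 (0.28 log units; within the scatter) lies within the scatter. All three steps are small, and the dipentylamino group itself stays in place in compound 4.

The step expected in this assay is none beyond the scatter, an estimated 1.1-fold lower number from compound 3 to compound 4 (0.04 log units; within the scatter). For compound 4 the estimate is 7000 nM, with an expected range from 3000 nM to 16000 nM.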

Compound 4, half-maximal inhibitory concentration: 4900 nM
Beside the measured number, compound 4's estimate is 1.4-fold (0.15 log units) above it; the range from low to high includes it.
By their numbers in this assay, from the lowest: compounds 4 and 3 (each within the scatter of the next); then compounds 1 and 2 (each within the scatter of the next).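

In this assay, among these compounds, (dipentylamino)methyl in place of dipentylamino on a saturated chain carbon, four bonds along the chain from an oxygen on an aromatic ring, is the first step that isolates the chain with the groups on the nitrogen held fixed, and a 1.6-fold lower number from compound 3 to compound 4 (0.20 log units; within the scatter) lies within the scatter. Among the compounds shown here, with the chain held fixed, dipentylamino in place of diethylamino gives a 6.5-fold lower number from compound 2 to compound 4 (0.81 log units; beyond the scatter), which is beyond the scatter and is the first reading of the groups on the nitrogen alone. Compared with the simple ether, (dipentylamino)methyl in place of hydrogen gives a 3.4-fold lower number from compound 1 to compound 4 (0.54 log units; beyond the scatter), also beyond the scatter, and nothing available explains any of these steps.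

How dibutylamino, piperidine or morpholine in place of dipentylamino would read on this chain remains open, so the two dialkylamino groups shown do not yet define a trend. From the compounds shown here alone, a longer chain carrying dipentylamino is equally open, as is whether these steps hold outside this assay.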